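The source may report more compounds than this note shows. Statements on the series, on what has been measured and on what is new or still open speak of the compounds shown alone.

Compound 1, `COC(=O)C1=C(N)Oc2c(OC)cc(Br)cc2C1CC(=O)c1cccc(OC)c1`, in a functional assay on MCF7 cells (Homo sapiens) for antiproliferative activity, read by sulforhodamine B assay, with a stated time of 72 h, tested at 10 uM; on this read-out higher numbers stand for a weaker effect at the one concentration tested and lower numbers for a stronger effect: 142%
Compound 2, `COC(=O)C1=C(N)Oc2c(OC)cc(Br)cc2C1CC(=O)c1ccc(Br)cc1`, in this assay: 50.2%
Compound 3, `COc1cccc(C(=O)CC2C(C#N)=C(N)Oc3c(OC)cc(Br)cc32)c1`, in this assay: 55.9%

From compound 1 to compound 2 the change is 4-bromophenyl in place of 3-methoxyphenyl on a carbonyl carbon, and the read-out moved a number 91.8 percentage points lower from compound 1 to compound 2 (beyond the scatter). The core of compound 3 differs from that of compound 1 by cyano in place of methoxycarbonyl on a double-bonded ring carbon, a step of a number 86.1 percentage points lower from compound 1 to compound 3 (beyond the scatter). Compound 2 and compound 3 lie within the scatter of each other. Compound 4, `COc1cc(Br)cc2c1OC(N)=C(C#N)C2CC(=O)c1ccc(Br)cc1`, has not been tested in this assay; it differs from compound 3 by 4-bromophenyl in place of 3-methoxyphenyl on a carbonyl carbon, the same change at the same place as that from compound 1 to compound 2. Whether a step of the size a number 91.8 percentage points lower from compound 1 to compound 2 (beyond the scatter) recurs cannot be read from three compounds: compound 1 starts far higher than compound 3, and a drop of that size from compound 3 would go below any number this read-out can report. Compound 4 is therefore expected to move a number 15.9 percentage points lower from compound 3 to compound 4 (beyond the scatter), a smaller step, resting on compound 3 at 55.9% and on the direction shown by a number 91.8 percentage points lower from compound 1 to compound 2 (beyond the scatter). The estimate for compound 4 is 40%, between 20% and 65%.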

Compound 4, a percentage reported as activity, at one concentration (the size of the read-out at that concentration, not a potency): 39.7%
Estimate against measurement, compound 4: 0.3 percentage points above, and the stated range covers the measured number.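

On the core carrying the cyano group, 4-bromophenyl in place of 3-methoxyphenyl on a carbonyl carbon again lowered the number in this assay, with a step of a number 16.2 percentage points lower from compound 3 to compound 4 (beyond the scatter), so the direction carried over but the size did not: the same change on two cores in this assay, a number 91.8 percentage points lower (beyond the scatter) from compound 1 to compound 2 and a number 16.2 percentage points lower (beyond the scatter) from compound 3 to compound 4, 75.6 percentage points apart, beyond the scatter of two such steps

The cyano change likewise kept its direction on the core carrying the 4-bromophenyl group, with a step of a number 10.5 percentage points lower from compound 2 to compound 4 (beyond the scatter), and it too lost most of its size: the same change on two cores in this assay, a number 86.1 percentage points lower (beyond the scatter) from compound 1 to compound 3 and a number 10.5 percentage points lower (beyond the scatter) from compound 2 to compound 4, 75.6 percentage points apart, beyond the scatter of two such steps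

These two comparisons come from the same four compounds and both rest on the high number of compound 1, so they count as one observation of non-additive changes and do not show how large either step would be on any further core.

The compounds shown leave open whether the same direction would hold with a plain phenyl on the carbonyl carbon, or with a carboxylic acid or an amide in place of the cyano. They also leave open whether these stronger effects at the one concentration tested would hold at other concentrations.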